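Spiro substituent on the amide nitrogen and tolerated concentration

The compounds below may be only part of what the source reports. "The series", "measured", "known", "first", "only" and "open" are said of these compounds alone.

Compound 3 `Cc1cc(C)cc(S(=O)(=O)c2c(C(N)=O)[nH]c3ccc(Cl)cc23)c1` gives 5520 nM in a toxicity assay on MT4 cells (Homo sapiens) for cytotoxicity, read by MTT assay, with a stated time of 7 days (a higher number here means that more compound is tolerated, a lower number that less compound is tolerated), the lowest of the two numbers shown. Among the measured compounds shown here, compound 2 `Cc1cc(C)cc(S(=O)(=O)c2c(C(=O)NC3CC4(CCNC4)C3)[nH]c3ccc(Cl)cc23)c1` gives 25300 nM in this assay, and the step of a 4.6-fold lower number from compound 2 to compound 3 (0.66 log units; beyond the scatter) is the one measured comparison at the amide-type nitrogen. Compound 1 `Cc1cc(C)cc(S(=O)(=O)c2c(C(=O)NC3CC4(C3)CN(C(=O)OC(C)(C)C)C4)[nH]c3ccc(Cl)cc23)c1` returns only a limit, > 224000 nM, which is no number but the case described by the limit of > 224000 nM in this assay, at which 1 of the 3 values shown sits. Compound 4 `Cc1cc(C)cc(S(=O)(=O)c2c(C(=O)NC3CC4(C3)CN(CC(N)=O)C4)[nH]c3ccc(Cl)cc23)c1` carries a group of 11 heavy atoms (8 carbon, 2 nitrogen, 1 oxygen; one four-membered non-aromatic ring of carbon only, one four-membered non-aromatic ring with 1 hetero atom) in place of a hydrogen atom, on an amide-type nitrogen. Because the removal of a substituent at this nitrogen gave a 4.6-fold lower number from compound 2 to compound 3 (0.66 log units; beyond the scatter), adding one is expected to move the number upward, beyond the scatter. The expected step for compound 4 is a 9.1-fold higher number from compound 3 to compound 4 (0.96 log units; beyond the scatter). The estimate for compound 4 is 50000 nM, within 15000 nM to 200000 nM.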

Compound 4, half-maximal cytotoxic concentration: 6080 nM
Compound 4: the middle estimate sits 8.2-fold (0.92 log units) above what was measured, and the stated range ends above it.
By their numbers in this assay, from the lowest: compounds 3 and 4 (each within the scatter of the next); then compound 2. At a limit, above all of these: compound 1.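

In this assay, a substituent on the amide-type nitrogen does not by itself shift the number: a 1.1-fold higher number from compound 3 to compound 4 (0.04 log units; within the scatter), whereas a 4.2-fold lower number from compound 2 to compound 4 (0.62 log units; beyond the scatter), so the group carried matters, not merely its presence. At the amine nitrogen in a ring, carbamoylmethyl in place of tert-butoxycarbonyl gives an at least 36-fold lower number from compound 1 to compound 4 (1.56 log units; beyond the scatter). Compound 1 gives a limit and not a number: the limit of > 224000 nM in this assay, at which 1 of the 4 values shown sits. Still open, as far as these compounds go, is where a carboxylic acid or a longer chain in place of carbamoylmethyl at that nitrogen would fall in this assay.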